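Thiomorpholine amide on the core of compound 2

A few compounds are considered here, and "the series" means these few. Any claim that something is new, unique, unknown or untested is made for them only; others in the source may bear on it.

Compound 2 `C[C@@H]1N[C@H](C(=O)N2CCC[C@H]2C#N)C[C@@H]1C(=O)N1CCC1` stands highest of the three measured in an assay on the whole organism (plasma, strain Sprague-Dawley) for inhibition of Dipeptidyl peptidase 4 (Rattus norvegicus), with a stated time of 6 h, at a dose of 1 mg/kg by the oral route; a higher number here means more inhibition at the dose given (going by the name of the read-out), a lower number less inhibition; compound 2 gives 94%. Compound 1 `CN(C)C(=O)C[C@@H]1CN[C@H](C(=O)N2CCC[C@H]2C#N)C1` gives 66% and compound 3 `CCN(CC)C(=O)[C@@H]1CN[C@H](C(=O)N2CCC[C@H]2C#N)C1` gives 43%, and both steps from compound 2 lie beyond the scatter. Compound 4 `C[C@@H]1N[C@H](C(=O)N2CCC[C@H]2C#N)C[C@@H]1C(=O)N1CCSCC1` differs from compound 2 by thiomorpholin-4-yl in place of azetidin-1-yl on a carbonyl carbon. Among the compounds with values here, the only measured step, a number 23 percentage points lower from compound 1 to compound 3 (beyond the scatter), alters the amide on a saturated ring carbon of the core of compound 1, not the amide that changes here, so it bears only loosely on this step. That amide change was modest in size, so a modest fall is expected for compound 4, a number 12 percentage points lower from compound 2 to compound 4 (beyond the scatter), though a step within the scatter is also possible. Compound 4 is estimated at 82%, range 62% to 96%.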

Compound 4, a percentage reported as inhibition, in the whole organism at one dose (the size of the read-out at that dose, not a potency): 92%
For compound 4 the middle estimate is 10 percentage points below the measured one, within the range that was stated.
By their numbers in this assay, from the lowest: compound 3; then compound 1; then compounds 4 and 2 (each within the scatter of the next).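

Within the data shown here, the step of a number 2 percentage points lower from compound 2 to compound 4 (within the scatter) in this assay is the first reading of this amide, as the earlier compounds held no change on this carbonyl carbon. It shows that thiomorpholin-4-yl, a six-membered ring holding sulfur, can stand in place of azetidin-1-yl, a four-membered ring, without a shift beyond the scatter. No measurement given here accounts for this result. Going by these compounds, whether a carboxylic acid or an open-chain diethylamide on this carbonyl carbon would hold the read-out stays open. A read-out at one dose also leaves any difference in potency between these two compounds open.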